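The compounds below may be only part of what the source reports. "The series", "measured", "known", "first", "only" and "open" are said of these compounds alone.

Measured so far in an ADME assay on HEK293 cells (Homo sapiens) for cytotoxicity, with a stated time of 72 h; a lower number here means that less compound is needed, a higher number that more compound is needed for the effect
- Compound 1 `C=C[C@@](C)(/C=C/c1ccc(OS(=O)(=O)C(F)(F)F)cc1)CCC=C(C)C` gives > 36600 nM (a limit)
- Compound 2 `C=C[C@@](C)(/C=C/c1ccc(Nc2ccc(Cl)cc2)cc1)CCC=C(C)C` gives > 36600 nM (a limit)

Compound 2 has no number to its name, since > 36600 nM is a limit. Among the measured compounds shown here, the series so far stands at the limit of > 36600 nM in this assay, at which 2 of the 2 values shown sit, and has no readable value.

The next step leads to compound 3 `C=C[C@@](C)(/C=C/c1ccc(-c2ccc(Cl)cc2)cc1)CCC=C(C)C` where 4-chlorophenyl replaces (4-chlorophenyl)amino on an aromatic carbon, para to a large group 4-chlorophenyl in place of (4-chlorophenyl)amino on an aromatic carbon and the rest of the structure stays the same.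

For the measured compounds named here, one measured step bears on this change, as it also swaps the group on an aromatic carbon. This is a step that the two limits leave unreadable from compound 1 to compound 2 and it offers no size or direction to carry over. The expectation for compound 3 therefore rests on compound 2 and its limit of > 36600 nM and on nothing firmer. The expected step is a step that the limit leaves unreadable from compound 2 to compound 3 in this assay and amounts to none beyond the scatter, with no direction favoured. A report as a limit again is the likeliest outcome. The estimate for compound 3 is 40000 nM (range 15000 nM to 100000 nM) and it remains only an expectation.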

Compound 3, half-maximal effective concentration: > 36600 nM
Compound 3: only a limit was reported (the forecaster's own chance of this, stated with the estimate: 85%); the middle value does not contradict the limit.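

In this assay compound 3 gives > 36600 nM, which is a limit, and no step among compound 1, compound 2 and compound 3 can be read: the limit of > 36600 nM in this assay, at which 3 of the 3 values shown sit.

The compounds shown leave open whether any group on this aromatic carbon would give a readable value in this assay, and how large any difference between these three compounds might be.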